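A few compounds are considered here, and "the series" means these few. Any claim that something is new, unique, unknown or untested is made for them only; others in the source may bear on it.

Working notes on an ADME assay (liver) for metabolic stability, with Liver microsome (Rattus norvegicus) as the target, using microsomes and NADPH, with a stated time of 30 min, tested at 1 uM (on this read-out lower numbers stand for slow clearance and higher numbers for fast clearance), for this series. Compound 1 (`COc1cc(C(O)(C(F)(F)F)C(F)(F)F)cnc1N1CCN(S(=O)(=O)c2ccc(N)nc2)CC1`) carries methoxy and returns only a limit of the assay, < 14 mL.min-1.g-1 in this read-out. Compound 2 (`Nc1ccc(S(=O)(=O)N2CCN(c3ncc(C(O)(C(F)(F)F)C(F)(F)F)cc3C#CCO)CC2)cn1`) gives 65 mL.min-1.g-1 and compound 3 (`Nc1ccc(S(=O)(=O)N2CCN(c3ncc(C(O)(C(F)(F)F)C(F)(F)F)cc3-c3ccoc3)CC2)cn1`) gives 57 mL.min-1.g-1 here, so compound 3 stands level with compound 2, the two values lying within the scatter of each other. Replacing methoxy gave an at least 4.6-fold higher number from compound 1 to compound 2 (0.66 log units; beyond the scatter) with 3-hydroxyprop-1-yn-1-yl and an at least 4.0-fold higher number from compound 1 to compound 3 (0.60 log units; beyond the scatter) with furan-3-yl; both steps lie beyond the scatter, and both start from a limit rather than a number.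

Compound 4 (`Cc1csc(-c2cc(C(O)(C(F)(F)F)C(F)(F)F)cnc2N2CCN(S(=O)(=O)c3ccc(N)nc3)CC2)c1`) is the next case: 4-methylthiophen-2-yl in place of furan-3-yl on an aromatic carbon, ortho to a large group (4-methylthiophen-2-yl in place of furan-3-yl on an aromatic carbon). The closest guide is the exchange of one non-methoxy group for another at that carbon, a 1.1-fold lower number from compound 2 to compound 3 (0.06 log units; within the scatter) in size, which stayed within the scatter. The two steps away from methoxy say little here, since compound 4 keeps a group other than methoxy at that carbon. The step expected is a 1.1-fold higher number from compound 3 to compound 4 (0.04 log units; within the scatter) and no change beyond the scatter is expected in this assay for this exchange. Compound 4 is estimated at 62 mL.min-1.g-1 with an expected range from 32 mL.min-1.g-1 to 115 mL.min-1.g-1 in this read-out.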

Compound 4, intrinsic clearance in microsomes: 399 mL.min-1.g-1
Compound 4: the middle estimate sits 6.4-fold (0.81 log units) below what was measured; the measured number lies above the stated range.
By their numbers in this assay, from the lowest: compounds 3 and 2 (each within the scatter of the next); then compound 4. At a limit, below all of these: compound 1.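

Among the groups other than methoxy at this carbon, the earlier exchange had shown no separation, but 4-methylthiophen-2-yl in place of furan-3-yl gives a 7.0-fold higher number from compound 3 to compound 4 (0.85 log units; beyond the scatter) in this assay, so the read-out at this position does respond to the choice of five-membered aromatic ring. The result does not depend on furan-3-yl as the point of comparison, since 4-methylthiophen-2-yl in place of 3-hydroxyprop-1-yn-1-yl gives a 6.1-fold higher number from compound 2 to compound 4 (0.79 log units; beyond the scatter), and among the three groups other than methoxy only 4-methylthiophen-2-yl stands apart. Against methoxy the change gives an at least 28-fold higher number from compound 1 to compound 4 (1.45 log units; beyond the scatter), the largest step shown, but its starting point, compound 1, is a limit and not a number: the limit of < 14 mL.min-1.g-1 in this assay, at which 1 of the 4 values shown sits.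

The step from compound 3 to compound 4 changes the ring hetero atom from oxygen to sulfur, the point of attachment and the methyl group together, so the compounds shown cannot assign the step to any one of these. Open as well is where a plain thiophen-2-yl would fall at this carbon, and what a carboxylic acid or an amine carried on the five-membered ring would do to the read-out.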